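Replacing the Trifluoromethylphenyl Group with Dichlorocyanophenyl

The source may report more compounds than this note shows. Statements on the series, on what has been measured and on what is new or still open speak of the compounds shown alone.

Measured so far in a functional assay on HEK293 cells for antagonist activity at transient receptor potential cation channel subfamily V member 1 (Homo sapiens), read by calcium flux; a lower number here means a stronger inhibitor, a higher number a weaker inhibitor:
compound 1 `Cc1cccc(C)c1Nc1nc2c(Nc3ccc(C(F)(F)F)cc3)ncnc2s1` — 23 nM
compound 2 `FC(F)(F)c1ccc(Nc2ncnc3sc(Nc4ccccc4C(F)(F)F)nc23)cc1` — 74 nM

Going by the values given here, compound 2 holds the higher of the two numbers in this assay; the only step recorded at this position, a 3.2-fold higher number from compound 1 to compound 2 (0.51 log units; beyond the scatter), was modest but beyond the scatter. Compound 3 `N#Cc1cc(Cl)c(Nc2nc3c(Nc4ccc(C(F)(F)F)cc4)ncnc3s2)c(Cl)c1` differs from compound 2 in one place: 2,6-dichloro-4-cyanophenyl in place of 2-(trifluoromethyl)phenyl on a nitrogen on an aromatic ring. Among the compounds with values here, no measured step covers the 2,6-dichloro-4-cyanophenyl group, so that one step is the only guide, and it merely shows that changes on this nitrogen move the number moderately. Compound 3 is therefore expected near 60 nM (range 15 nM to 250 nM), the expected step of a 1.2-fold lower number from compound 2 to compound 3 (0.09 log units; within the scatter) staying within the scatter.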

Compound 3, half-maximal inhibitory concentration: 95 nM
Compound 3: middle estimate off by 1.6-fold (0.20 log units), on the low side, and the stated range covers the measured number.
By their numbers in this assay, from the lowest: compound 1; then compounds 2 and 3 (each within the scatter of the next).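

In this assay, the 2,6-dichloro-4-cyanophenyl and 2-(trifluoromethyl)phenyl groups on this nitrogen cannot be told apart, with a 1.3-fold higher number from compound 2 to compound 3 (0.11 log units; within the scatter) as the step between them. The 2,6-dimethylphenyl group remains the best of the three, with a 4.1-fold higher number from compound 1 to compound 3 (0.62 log units; beyond the scatter) as the step away from it. No supporting evidence is available to explain this order.

The compounds shown leave open what the nitrile contributes, which a 2,6-dichlorophenyl group would test. They also leave open how an unsubstituted phenyl or a cyclohexyl group would fare on this nitrogen.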